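The compounds below may be only part of what the source reports. "The series", "measured", "known", "first", "only" and "open" are said of these compounds alone.

Compound 3 `Cc1cccc(NC(=O)CSC(=S)N[C@H]2CCOC2=O)c1` stands at the limit of a functional assay on SMMC-7721 cells (Homo sapiens) for cytotoxicity, read by MTT assay, with a stated time of 72 h (on this read-out lower numbers stand for stronger inhibition and higher numbers for weaker inhibition), where compound 3 gives > 128000 nM. The line the limit of > 128000 nM in this assay, at which 2 of the 3 values shown sit, shows that compound 1 `O=C(CSC(=S)N[C@H]1CCOC1=O)Nc1ccc(Cl)cc1` also stops at this limit, giving > 128000 nM. Within the data shown here, compound 2 `O=C(CSC(=S)N[C@H]1CCOC1=O)Nc1ccc(Br)cc1` gives 28300 nM and is the only compound here with a number rather than a limit. The measured steps are an at least 4.5-fold lower number from compound 1 to compound 2 (0.65 log units; beyond the scatter), an at least 4.5-fold higher number from compound 2 to compound 3 (0.65 log units; beyond the scatter) and a step that the two limits leave unreadable from compound 1 to compound 3; none of them removes a methyl from an aromatic carbon. Compound 4 `O=C(CSC(=S)N[C@H]1CCOC1=O)Nc1ccccc1` differs from compound 3 by hydrogen in place of methyl on an aromatic carbon. With compound 3 at a limit, the step that the limit leaves unreadable from compound 3 to compound 4 is expected to stay unreadable. Compound 4 is therefore estimated at 150000 nM, within 40000 nM to 500000 nM, most likely again reported only as a limit.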

Compound 4, half-maximal inhibitory concentration: > 128000 nM
Compound 4 was reported as a limit (the forecaster's own chance of this, stated with the estimate: 70%); the middle value is on the limit's open side.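

In this assay compound 4 gives > 128000 nM, which is a limit and not a number. Hydrogen in place of bromo on the aromatic carbon gives an at least 4.5-fold higher number from compound 2 to compound 4 (0.65 log units; beyond the scatter), so the plain phenyl compound does not share the measurable value that compound 2 shows. The steps to compound 4 from compound 3 and from compound 1 join two limits and cannot be read: the limit of > 128000 nM in this assay, at which 3 of the 4 values shown sit.

From the compounds shown here alone, it remains open whether iodo, methoxy or an amine on the phenyl ring would also give a number. Going by these compounds, it also remains open how far the compounds at the limit differ from one another.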